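Chloro in Place of Hydroxy: Expected Cell Tolerance

This account rests on a few compounds, and the source may have more. Where it says the series, first, only, none or still open, it means among the compounds named here.

Two compounds have been measured in an ADME assay on LOX IMVI cells (Homo sapiens) for cytotoxicity, read by sulforhodamine B assay, with a stated time of 24 h; a lower number here means that less compound is tolerated, a higher number that more compound is tolerated:
Compound 1 `COc1ccc(C(=O)/C=C/c2cc3ccccc3[nH]c2=O)cc1` gives 33300 nM.
Compound 2 `O=C(/C=C/c1cc2ccccc2[nH]c1=O)c1ccc(O)cc1` gives > 100000 nM, which is a limit of the assay.

Compound 2 therefore stands only at a limit: its value sits at the limit of > 100000 nM in this assay, at which 1 of the 2 values shown sits, a limit of the assay and not a number. Compound 3 `O=C(/C=C/c1cc2ccccc2[nH]c1=O)c1ccc(Cl)cc1` differs from compound 2 by chloro in place of hydroxy on an aromatic carbon. Going by the values given here, the only measured step, an at least 3.0-fold higher number from compound 1 to compound 2 (0.47 log units; beyond the scatter), touches the same oxygen from the other side: compound 1 carries a methyl on that oxygen. That step went toward a higher number, and compound 3 no longer carries the hydroxy that came in with it, so compound 3 is expected to sit between compound 1 and the limit reached by compound 2. The expected step is an at least 2.0-fold lower number from compound 2 to compound 3 (0.30 log units; that floor lies within the scatter), though the limit on compound 2 leaves its size uncertain. For compound 3 the estimate in this assay is 50000 nM, with a range from 15000 nM to 150000 nM.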

Compound 3, concentration lethal to 50% of the cells: > 100000 nM
Compound 3: only a limit was reported; the forecaster's own chance of this, stated with the estimate: 35%; at least 2.0-fold (0.30 log units) between middle value and limit.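

Compound 3, like compound 2, stands at a limit of this assay and not at a number: the limit of > 100000 nM in this assay, at which 2 of the 3 values shown sit. The step between these two compounds cannot be read, so the change from hydroxy to chloro has no measured size here. The new information comes from the comparison with compound 1, where chloro in place of methoxy gives an at least 3.0-fold higher number from compound 1 to compound 3 (0.47 log units; beyond the scatter) on the same aromatic carbon, which shows that the hydroxy of compound 2 is not needed for a number on this higher side.

The compounds shown leave open how far above compound 1 either compound 2 or compound 3 really lies. They also leave open whether an amine, a carboxylic acid or a longer chain such as ethoxy at this place would keep the number on the higher side.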